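Fluoro for hydrogen on the aryl ring: adenosine binding

This account rests on a few compounds, and the source may have more. Where it says the series, first, only, none or still open, it means among the compounds named here.

Three measured compounds share one core and differ only on the six-membered aromatic ring. In an assay on membranes from brain for binding affinity to adenosine receptor A1 (Rattus norvegicus), read by radioligand binding, tested at 20 uM (a lower number here means less inhibition, a higher number more inhibition at the concentration tested (going by the name of the read-out)), compound 1 `Cn1c(=O)[nH]c2c(cnn2-c2ccc(Cl)cc2)c1=N` gives 37%, compound 2 `Cn1c(=O)[nH]c2c(cnn2-c2cccc(Cl)c2)c1=N` gives 53%, and compound 3 `Cn1c(=O)[nH]c2c(cnn2-c2ccccc2)c1=N` gives 30%. Compound 3 stands lowest of the three numbers; its gap to compound 1 lies within the scatter, while its gap to compound 2 lies beyond it. Compound 4 `Cn1c(=O)[nH]c2c(cnn2-c2cccc(F)c2)c1=N` differs from compound 3 in one place: fluoro in place of hydrogen on an aromatic carbon. Going by the values given here, two measured steps bear on this change, both of them removals of chloro: a number 7 percentage points lower from compound 1 to compound 3 (within the scatter) and a number 23 percentage points lower from compound 2 to compound 3 (beyond the scatter). Since the entering group is fluoro rather than chloro, the full size of the step seen between compound 2 and compound 3 need not carry over. A rise that is modest at most is expected. Compound 4 is expected to give 40% in this assay, within a range from 25% to 55%. The expected step of a number 10 percentage points higher from compound 3 to compound 4 (within the scatter) would thus lie near the edge of the scatter.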

Compound 4, a percentage reported as inhibition, at one concentration (the size of the read-out at that concentration, not a potency): 44%
Compound 4: middle estimate off by 4 percentage points, on the low side; the range from low to high includes it.
By their numbers in this assay, from the lowest: compounds 3, 1, 4 and 2 (each within the scatter of the next, the first and the last beyond it).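

At this position, meta to a large group, a second halogen now supports the rise over hydrogen: a number 14 percentage points higher from compound 3 to compound 4 (beyond the scatter) in this assay joins the chloro step, which until now stood alone. Fluoro in place of chloro gives a number 9 percentage points lower from compound 2 to compound 4 (within the scatter), so these two halogens cannot be told apart here, even though fluoro enters as a single heavy atom on the same aromatic carbon. The gain at this place therefore does not depend on chloro specifically, though this rests only on compound 2 and compound 4.

From the compounds shown here alone, whether a non-halogen group such as methoxy, an amine or a carboxylic acid at this place would keep, lose or add to the rise remains open, as does what fluoro would give at the ring place that carries chloro in compound 1. Nothing shown here accounts for the rise on the aryl ring.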